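Cyclopentyl for isopropyl on the shared core

A few compounds are considered here, and "the series" means these few. Any claim that something is new, unique, unknown or untested is made for them only; others in the source may bear on it.

Two compounds of the series have numbers in a functional assay on cells (T-cell, Homo sapiens) for inhibition; on this read-out lower numbers stand for stronger inhibition and higher numbers for weaker inhibition. Compound 1 `COc1ccc(-c2cnc3nc(N)nc(NC(C)C)c3n2)cc1OC` gives 600 nM in this assay. Compound 2 `COc1ccc(-c2cnc3nc(N)nc(N4CCN(c5cc(Cl)cc(Cl)c5)CC4)c3n2)cc1OC` carries a substituted piperazine where compound 1 carries the isopropylamino group. In this assay compound 2 gives 3400 nM; that is the higher of the two numbers, and the gap between the two values is beyond the scatter. For the measured compounds named here, no step between the two has been computed, so only the two values themselves are compared. Compound 1 thus stands at the lowest of the two numbers.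

Compound 3 `COc1ccc(-c2cnc3nc(N)nc(NC4CCCC4)c3n2)cc1OC` has not yet been measured in this assay. It differs from compound 1 in one place: cyclopentyl in place of isopropyl on a nitrogen on an aromatic ring. The group that enters, cyclopentyl, is a five-membered non-aromatic ring of carbon only, and like isopropyl it brings no hydrogen-bond donor, no acceptor and no charge.

Going by the values given here, no measured step of this kind exists. The expected step of a 1.5-fold lower number from compound 1 to compound 3 (0.18 log units; within the scatter) is small, towards a somewhat lower number, and may well fall within the scatter. Compound 3 is therefore estimated at 400 nM in this assay, with a range from 150 nM to 1500 nM.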

Compound 3, half-maximal inhibitory concentration: 800 nM
Beside the measured number, compound 3's estimate is 2.0-fold (0.30 log units) below it, within the range that was stated.
By their numbers in this assay, from the lowest: compounds 1 and 3 (each within the scatter of the next); then compound 2.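

In this assay the change of isopropylamino to cyclopentylamino gives a 1.3-fold higher number from compound 1 to compound 3 (0.12 log units; within the scatter) and thus supplies the first step read at this position on the shared core. The two groups cannot be told apart on this read-out, so the five-membered non-aromatic ring of carbon only is accepted on this nitrogen with no change that the assay can resolve, and this one step says no more than that about the position. No measurement is available that would account for this result.

As far as these compounds go, both groups in this step are made of carbon only, so it remains open whether the same flat reading would hold for an amine or a carboxylic acid carried on the ring, for a morpholine, or for a longer chain on this nitrogen. Also open is how an unsubstituted piperazine would read, as compound 2 gives 3400 nM with its piperazine and the substituent on it together, and the two parts cannot be separated on the compounds shown.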